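This account rests on a few compounds, and the source may have more. Where it says the series, first, only, none or still open, it means among the compounds named here.

Values in a functional assay on MCF7 cells (Homo sapiens) for inhibition, read by MTT assay, with a stated time of 72 h (a higher number here means a weaker inhibitor, a lower number a stronger inhibitor), so far
- compound 1 `C=C(Br)C(=O)Nc1cccc(/C=C/C(=O)Nc2ccccc2)c1` gives 27300 nM
- compound 2 `C=C(Br)C(=O)Nc1cccc(/C=C/C(=O)Nc2ccc(C)cc2)c1` gives 2500 nM

Compound 2 has the lower of these two numbers, which makes it the stronger inhibitor of the pair. The next compound to be measured is compound 3 `C=C(Br)C(=O)Nc1cccc(/C=C/C(=O)NCc2ccc(C)cc2)c1`, which has 4-methylbenzyl in place of 4-methylphenyl on an amide-type nitrogen. For the measured compounds named here, only one measured step bears on this change, and only loosely. That step (an 11-fold lower number from compound 1 to compound 2 (1.04 log units; beyond the scatter)) was large, yet it only put methyl in place of hydrogen on an aromatic carbon. It shows that a small edit to the group on this nitrogen can move the number a long way. Going by the values given here, no measured compound carries a 4-methylbenzyl group, so the direction remains uncertain. A moderate rise in the number is cautiously expected (a 2.0-fold higher number from compound 2 to compound 3 (0.30 log units; within the scatter)) in this assay. For compound 3 the estimated value is 5000 nM, with an expected range from 1500 nM to 18000 nM.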

Compound 3, half-maximal inhibitory concentration: 2200 nM
For compound 3 the middle estimate is 2.3-fold (0.36 log units) above the measured one; low and high end bracket the measured number.
By their numbers in this assay, from the lowest: compounds 3 and 2 (each within the scatter of the next); then compound 1.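

In this assay, 4-methylbenzyl in place of 4-methylphenyl on the amide-type nitrogen gives a 1.1-fold lower number from compound 2 to compound 3 (0.06 log units; within the scatter), so this assay cannot tell the two groups apart, and the group on this nitrogen need not be attached directly through its aromatic ring. Set against the plain phenyl group, 4-methylbenzyl gives a 12-fold lower number from compound 1 to compound 3 (1.09 log units; beyond the scatter), so the large step seen earlier is not unique to 4-methylphenyl. No available measurement explains why these two groups give such similar numbers.

As far as these compounds go, it remains open what plain benzyl, without the methyl, would give, and so how much of the large step belongs to the methyl itself. Also open, from the compounds shown here alone, is how a longer chain such as 2-phenylethyl on this nitrogen, or an amine or a carboxylic acid in place of the methyl, would behave.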